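A Halogen Swap on the Benzyl Ring of Compound 2

The compounds below may be only part of what the source reports. "The series", "measured", "known", "first", "only" and "open" are said of these compounds alone.

Three measured compounds share one core and differ only in the group on the amine nitrogen. Compound 1 `Clc1ccccc1Cn1nnc2c(NC3CCCCC3)nc(-c3ccccc3)nc21` carries a cyclohexyl there, and in an assay on isolated protein for binding affinity to adenosine receptor A1 (Bos taurus) (a lower number here means a stronger inhibitor, a higher number a weaker inhibitor), compound 1 gives 34000000 nM. Compound 2 `CCNc1nc(-c2ccccc2)nc2c1nnn2Cc1ccccc1Cl` carries an ethyl instead, and in this assay compound 2 gives 463000000 nM, the highest of the three numbers. Compound 3 `OCCNc1nc(-c2ccccc2)nc2c1nnn2Cc1ccccc1Cl` carries a 2-hydroxyethyl, and in this assay compound 3 gives 116000000 nM. The measured steps are a 14-fold higher number from compound 1 to compound 2 (1.13 log units; beyond the scatter), a 3.4-fold higher number from compound 1 to compound 3 (0.53 log units; beyond the scatter) and a 4.0-fold lower number from compound 2 to compound 3 (0.60 log units; beyond the scatter).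

Compound 4 `CCNc1nc(-c2ccccc2)nc2c1nnn2Cc1ccccc1F` is compound 2 with a single change: fluoro in place of chloro on an aromatic carbon. Going by the values given here, none of the three measured steps touches this ring; all of them alter the group on the amine nitrogen, so no measured step bears directly on the exchange of chloro for fluoro. Among the compounds with values here, the swap leaves ring count, donors, acceptors and charge unchanged, and with no comparable measured step there is no ground to expect a shift beyond the scatter in either direction. Compound 4 is therefore expected to give about 463000000 nM in this assay, with a range from 150000000 nM to 1400000000 nM. This estimate means a step of no change at the digits printed from compound 2 to compound 4 (within the scatter), expected to stay within the scatter.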

Compound 4, inhibition constant: 11000000 nM
Estimate against measurement, compound 4: 42-fold (1.62 log units) above; the whole stated range lies above it.
By their numbers in this assay, from the lowest: compound 4; then compound 1; then compound 3; then compound 2.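

In this assay, going by these compounds alone, the exchange of 2-chlorobenzyl for 2-fluorobenzyl gives a 42-fold lower number from compound 2 to compound 4 (1.62 log units; beyond the scatter), which shows that the halogen on this aromatic carbon strongly affects the reading, at a place that none of the earlier steps touched. This step is larger than any of the steps on the amine nitrogen, including the largest of them, a 14-fold higher number from compound 1 to compound 2 (1.13 log units; beyond the scatter), so with ethyl on the nitrogen, replacing one heavy atom on the benzyl ring counts for more than replacing cyclohexyl with ethyl, even though the hydrogen-bond donors, acceptors and net charge stay the same. No measured evidence is available on why fluoro and chloro differ so sharply here.

The compounds shown pair fluoro only with ethyl on the nitrogen, so it remains open whether the same exchange would shift the number as far with the cyclohexyl of compound 1 or the 2-hydroxyethyl of compound 3. On these data alone, it also remains open how hydrogen, bromo or methoxy at this aromatic carbon would compare with fluoro and chloro, and so whether the step reflects something particular to these two halogens.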